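Swapping the propyl for an amino group on the core

A few compounds are considered here, and "the series" means these few. Any claim that something is new, unique, unknown or untested is made for them only; others in the source may bear on it.

Three compounds share a core carrying a six-membered aromatic ring with one nitrogen. In an assay on membranes from brain for displacement of a labelled ligand from Neuronal acetylcholine receptor; alpha4/beta2 (Rattus norvegicus) (a lower number here means a stronger inhibitor, a higher number a weaker inhibitor), compound 1 `CCN(CC)C(=O)c1ccncc1OC[C@@H]1CCCN1C` gives 2830 nM, compound 2 `CCCCc1cncc(OC[C@@H]2CCCN2C)c1` gives 0.16 nM, and compound 3 `CCCc1cncc(OC[C@@H]2CCCN2C)c1` gives 0.12 nM, the lowest of the three numbers, with compound 2 within the scatter of it. The change a 1.3-fold lower number from compound 2 to compound 3 (0.12 log units; within the scatter) shows that shortening the chain by one carbon barely matters. Compound 4 `CN1CCC[C@H]1COc1cncc(N)c1` differs from compound 3 by amino in place of propyl on an aromatic carbon. For the measured compounds named here, no measured step covers this exchange; compound 1, which carries a polar group at this position, sits far above compound 3 in this assay. A weaker number is therefore expected, estimated as a 25-fold higher number from compound 3 to compound 4 (1.40 log units; beyond the scatter), giving compound 4 about 3 nM in this assay, likely between 0.4 nM and 30 nM.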

Compound 4, inhibition constant: 0.63 nM
Beside the measured number, compound 4's estimate is 4.8-fold (0.68 log units) above it, within the range that was stated.
By their numbers in this assay, from the lowest: compounds 3 and 2 (each within the scatter of the next); then compound 4; then compound 1.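

In this assay, replacing propyl with amino on this aromatic carbon gives a 5.3-fold higher number from compound 3 to compound 4 (0.72 log units; beyond the scatter), and replacing butyl with amino gives a 3.9-fold higher number from compound 2 to compound 4 (0.60 log units; beyond the scatter). Both steps lie beyond the scatter but are modest, so a low number at this position does not depend on an alkyl chain, and a single nitrogen group can stand in its place. Nothing measured here explains the size of these steps.

On these data alone, how a methylamino, dimethylamino or hydroxyl group on this carbon would compare with amino remains open. So does the effect of a shorter chain, such as ethyl.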